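The source may hold more compounds than are shown below. What is called first, only, known or untested is meant among the compounds shown, and "the series" means these compounds.

In a functional assay on A-431 cells (Homo sapiens) for inhibition, read by sulforhodamine B assay, with a stated time of 2 days (on this read-out higher numbers stand for weaker inhibition of growth and lower numbers for stronger inhibition of growth), compound 1 `CC1=C(C(=O)Nc2ccc(C)cc2)C(c2ccc(O)cc2O)NC(SCc2ccccc2)=N1` gives 20800 nM. Compound 2 `CC1=C(C(=O)Nc2cccc([N+](=O)[O-])c2)C(c2ccc(O)cc2O)NC(SCc2ccccc2)=N1` gives > 100000 nM, which is a limit of the assay and not a number. Compound 3 `CC1=C(C(=O)Nc2cccc([N+](=O)[O-])c2)C(c2ccc(O)cc2O)NC(NCc2ccccc2)=N1` carries benzylamino in place of benzylsulfanyl on a carbon with a double bond to nitrogen. For the measured compounds named here, the only measured step, an at least 4.8-fold higher number from compound 1 to compound 2 (0.68 log units; beyond the scatter), swapped 3-nitrophenyl in place of 4-methylphenyl on an amide-type nitrogen, a different change that does not gauge this one. Only a small move toward a lower number is therefore expected, an estimated at least 1.4-fold lower number from compound 2 to compound 3 (0.15 log units; that floor lies within the scatter), and the reading may stay at the limit. For compound 3 the estimate is 70000 nM, with a range of 25000 nM to 100000 nM.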

Compound 3, concentration for 50% growth inhibition: 35600 nM
Beside the measured number, compound 3's estimate is 2.0-fold (0.29 log units) above it; measured number inside the range.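

At this position, on the carbon between two ring nitrogen atoms, benzylamino in place of benzylsulfanyl gives an at least 2.8-fold lower number from compound 2 to compound 3 (0.44 log units; beyond the scatter) in this assay, so a change here alone moves the reading off the limit. The swap also brings a hydrogen-bond donor that benzylsulfanyl lacks, though nothing shown ties the change in reading to it. The size of the step stays a floor, since compound 2 stands at a limit: the limit of > 100000 nM in this assay, at which 1 of the 3 values shown sits.

As far as these compounds go, whether benzylamino acts the same way with the 4-methylphenyl group of compound 1 stays open. So does what a plain amine or a longer chain such as phenylethylamino would do at this position.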